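Swapping the 4-chlorobenzyl group for isopropyl

The source may hold more compounds than are shown below. What is called first, only, known or untested is meant among the compounds shown, and "the series" means these compounds.

Measured so far in an ADME assay on J774.A1 cells (Mus musculus) for inhibition, read by MTT assay, with a stated time of 72 h; a higher number here means that more compound is needed for the effect, a lower number that less compound is needed:
- compound 1 `Clc1ccc(CNc2nc(NCc3ccccc3)nc3ccccc23)cc1` gives 4600 nM
- compound 2 `COc1ccc(CNc2nc(NCc3ccccc3)c3ccccc3n2)cc1` gives 4100 nM
- compound 3 `Clc1ccc(CNc2nc(NCc3ccccc3)c3ccccc3n2)cc1` gives 3200 nM

Compound 1 lies within the scatter of both other compounds, so it holds no separate place among the three values. Compound 4 `CC(C)Nc1nc(NCc2ccccc2)nc2ccccc12` departs from compound 1 as follows: isopropyl in place of 4-chlorobenzyl on a nitrogen on an aromatic ring. Among the measured compounds shown here, the only measured step is a 1.3-fold lower number from compound 2 to compound 3 (0.11 log units; within the scatter) for chloro in place of methoxy on an aromatic carbon, and it stays within the scatter. For the measured compounds named here, that step keeps the aromatic ring, whereas here the ring leaves with the 4-chlorobenzyl, so no measured step gives direct guidance. A moderately higher number is expected in this assay, with low confidence. The estimated change is a 2.0-fold higher number from compound 1 to compound 4 (0.29 log units; within the scatter) and may prove smaller. For compound 4 the estimate is 9000 nM with an expected range from 3500 nM to 25000 nM.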

Compound 4, half-maximal effective concentration: 7200 nM
Beside the measured number, compound 4's estimate is 1.3-fold (0.10 log units) above it; low and high end bracket the measured number.
By their numbers in this assay, from the lowest: compounds 3, 2, 1 and 4 (each within the scatter of the next, the first and the last beyond it).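

In this assay this nitrogen keeps its number within the scatter when the aromatic ring and the chlorine leave: isopropyl in place of 4-chlorobenzyl gives a 1.6-fold higher number from compound 1 to compound 4 (0.19 log units; within the scatter). The earlier step changed only a group on an aromatic carbon, whereas this one shows that the (4-chlorobenzyl)amino group is not required for a value in this range. No available measurement offers an explanation for this result.

Open, on these data alone, is how a carboxylic acid, a primary amine or a longer alkyl chain on this nitrogen would read, and whether the same swap on compound 3 gives a step of like size.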